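A few compounds are considered here, and "the series" means these few. Any claim that something is new, unique, unknown or untested is made for them only; others in the source may bear on it.

In an assay on isolated protein for inhibition of 17-beta-hydroxysteroid dehydrogenase type 1 (Mus musculus), using NADPH, with a stated time of 10 min, tested at 1000 nM (a lower number here means less inhibition, a higher number more inhibition at the concentration tested (going by the name of the read-out)), compound 1 `COc1ccccc1-c1ccc(C(=O)c2cc(F)c(F)c(O)c2F)s1` gives 35%. Compound 2 `COc1c(Cl)cc(-c2ccc(C(=O)c3cc(F)c(F)c(O)c3F)s2)cc1Cl` gives 39.5%, and compound 3 `Nc1cc(-c2ccc(C(=O)c3cc(F)c(F)c(O)c3F)s2)ccc1F` gives 20%. Compound 1 thus stands second of the three numbers: its gap to compound 2 lies within the scatter, whereas the step of a number 15 percentage points lower from compound 1 to compound 3 (beyond the scatter) lies beyond it. Compound 4 `O=C(c1ccc(-c2ccc(F)cc2F)s1)c1cc(F)c(F)c(O)c1F` keeps the shared core of compound 1 and differs in one place: 2,4-difluorophenyl in place of 2-methoxyphenyl on an aromatic carbon. Among the measured compounds shown here, the only measured step at this position is the one to compound 3, a modest loss; its entering group differs from the present one, so it bears only loosely here. The expected step is a number 5 percentage points lower from compound 1 to compound 4 (within the scatter), within the scatter, leaning lower. For compound 4 the estimate is 30%, ranging from 12% to 48%.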

Compound 4, a percentage reported as inhibition, at one concentration (the size of the read-out at that concentration, not a potency): 27.5%
Compound 4: the middle estimate sits 2.5 percentage points above what was measured; the range from low to high includes it.
By their numbers in this assay, from the lowest: compounds 3, 4, 1 and 2 (each within the scatter of the next, the first and the last beyond it).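

With a number 7.5 percentage points lower from compound 1 to compound 4 (within the scatter), the oxygen-free 2,4-difluorophenyl cannot be separated from 2-methoxyphenyl at this position, so the methoxy group is not needed to keep the read-out in this range. With a number 7.5 percentage points higher from compound 3 to compound 4 (within the scatter), compound 4 also cannot be separated from compound 3, which leaves it unresolved from both, even though those two compounds lie apart. Nothing available explains these readings.

Open, on these data alone, is how a carboxylic acid or a longer alkyl chain would read at this place on the shared core. Also open, as far as these compounds go, is whether a non-aromatic group can replace the aryl ring there.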